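Changing the Saturated Ring at the End of the Chain

The source may hold more compounds than are shown below. What is called first, only, known or untested is meant among the compounds shown, and "the series" means these compounds.

Values in a functional assay on SH-SY5Y cells (Homo sapiens) for antiproliferative activity, read by MTT assay, with a stated time of 72 h; a higher number here means a weaker inhibitor, a lower number a stronger inhibitor:
compound 1 `COc1cc2c(Nc3ccc(C#N)cc3)ncnc2cc1OCCCN1CCC(C)CC1`: 7900 nM
compound 2 `COc1cc2c(Nc3ccc(C#N)cc3)ncnc2cc1OCCCN1CCC(CO)CC1`: 21600 nM
compound 3 `COc1cc2c(Nc3ccc(C#N)cc3)ncnc2cc1OCCCN1CCCCC1CCO`: only a limit, > 100000 nM

Compound 1 holds the lowest of the two numbers given. Hydroxy in place of hydrogen on a saturated chain carbon bound to a saturated ring carbon gave a 2.7-fold higher number from compound 1 to compound 2 (0.44 log units; beyond the scatter). Exchanging the whole ring gave an at least 12-fold higher number from compound 1 to compound 3 (1.10 log units; beyond the scatter) and an at least 4.6-fold higher number from compound 2 to compound 3 (0.66 log units; beyond the scatter), the latter value being a limit (the limit of > 100000 nM in this assay, at which 1 of the 3 values shown sits).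

Compound 4 `CCN1CCN(CCCOc2cc3ncnc(Nc4ccc(C#N)cc4)c3cc2OC)CC1` differs from compound 1 by 4-ethylpiperazin-1-yl in place of 4-methylpiperidin-1-yl on a saturated chain carbon, three bonds along the chain from an oxygen on an aromatic ring. Among the compounds with values here, no measured step makes this exact exchange; both known changes to this ring weakened inhibition, one modestly and one strongly. A modest weakening or none beyond the scatter is therefore expected, as a 1.4-fold higher number from compound 1 to compound 4 (0.14 log units; within the scatter). Compound 4 is estimated at 11000 nM, within 4000 nM to 30000 nM.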

Compound 4, half-maximal inhibitory concentration: 5440 nM
Compound 4: the middle estimate sits 2.0-fold (0.31 log units) above what was measured; low and high end bracket the measured number.
By their numbers in this assay, from the lowest: compounds 4 and 1 (each within the scatter of the next); then compound 2. At a limit, above all of these: compound 3.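

Changing the ring at this end of the chain need not weaken inhibition: 4-ethylpiperazin-1-yl in place of 4-methylpiperidin-1-yl gave a 1.5-fold lower number from compound 1 to compound 4 (0.16 log units; within the scatter), so a second ring nitrogen is accepted here without a loss. Against the two rings bearing a hydroxy group, the new ring stands clearly apart, with a 4.0-fold lower number from compound 2 to compound 4 (0.60 log units; beyond the scatter) and an at least 18-fold lower number from compound 3 to compound 4 (1.26 log units; beyond the scatter). Compound 3 is known only as a limit: the limit of > 100000 nM in this assay, at which 1 of the 4 values shown sits.

As far as these compounds go, whether the ethyl group or the second ring nitrogen matters more stays open. From the compounds shown here alone, how a morpholine ring at the end of the chain would compare also remains unknown.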